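A few compounds are considered here, and "the series" means these few. Any claim that something is new, unique, unknown or untested is made for them only; others in the source may bear on it.

Measured compounds in an assay on lysate for inhibition of phosphatidylcholine:ceramide cholinephosphotransferase 2 (Homo sapiens), read by HPLC, with stated times of 30 min and 2 h; a higher number here means a weaker inhibitor, a lower number a stronger inhibitor:
compound 1 `O=C(Nc1cccnc1)c1ccccc1OCc1cc(Cl)ccc1Cl`: 990 nM
compound 2 `COCCCOc1ccc(Cl)cc1COc1ccccc1C(=O)Nc1cccnc1`: 4100 nM

Going by the values given here, compound 2 stands at the highest of the two numbers so far; its only neighbour is compound 1, and the step of a 4.1-fold higher number from compound 1 to compound 2 (0.62 log units; beyond the scatter) separates them, so compound 2 is the weaker inhibitor of the pair.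

Compound 3 `CCCCCCOc1ccc(Cl)cc1COc1ccccc1C(=O)Nc1cccnc1` is next. Its difference from compound 2 is propyl in place of methoxy on a saturated chain carbon, three bonds along the chain from an oxygen on an aromatic ring; in other words the 3-methoxypropoxy chain of compound 2 becomes a hexyloxy chain of the same length, with the chain-end methoxy replaced by propyl.

Among the compounds with values here, only one measured step exists, a 4.1-fold higher number from compound 1 to compound 2 (0.62 log units; beyond the scatter), and it concerns the exchange of chloro for the whole 3-methoxypropoxy chain on the aromatic carbon, not a change at the chain end. Within the data shown here, no measured pair shows what the end of that chain does. With the chain length kept, the expectation for this assay is a step of no more than the scatter in either direction, worded as a 1.2-fold lower number from compound 2 to compound 3 (0.07 log units; within the scatter).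

Compound 3 is therefore estimated at 3500 nM in this assay, with a range from 1200 nM to 12000 nM.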

Compound 3, half-maximal inhibitory concentration: 520 nM
For compound 3 the middle estimate is 6.7-fold (0.83 log units) above the measured one, outside the stated range (below it).
By their numbers in this assay, from the lowest: compounds 3 and 1 (each within the scatter of the next); then compound 2.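

In this assay, the end of the chain carries weight: propyl in place of methoxy on a saturated chain carbon, three bonds along the chain from an oxygen on an aromatic ring, gives a 7.9-fold lower number from compound 2 to compound 3 (0.90 log units; beyond the scatter), so the number at this position depends on what ends the chain and not only on a chain being present. The penalty seen for 3-methoxypropoxy in place of chloro, a 4.1-fold higher number from compound 1 to compound 2 (0.62 log units; beyond the scatter), therefore does not extend to every chain here, since hexyloxy in place of chloro on an aromatic carbon gives a 1.9-fold lower number from compound 1 to compound 3 (0.28 log units; within the scatter), and this position accepts the hexyloxy chain with no change beyond the scatter. No evidence is available on what lies behind the effect of the exchange at the chain end.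

This single pair cannot separate the loss of the methoxy oxygen from the gain in all-carbon chain end, as both change together between compound 2 and compound 3. The compounds shown also leave open how a longer chain such as octyloxy, or a chain ending in an amine or a carboxylic acid, would read in this assay.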